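The source may hold more compounds than are shown below. What is called first, only, known or untested is meant among the compounds shown, and "the series" means these compounds.

For the measured compounds named here, in a functional assay on MCF7 cells (Homo sapiens) for inhibition, with a stated time of 48 h (on this read-out lower numbers stand for stronger inhibition and higher numbers for weaker inhibition), compound 1 (`COc1cc(Sc2c[nH]c3ccc(Cl)cc23)cc(OC)c1OC`) gives 77 nM and compound 2 (`COc1cc(Sc2c[nH]c3ccc([N+](=O)[O-])cc23)cc(OC)c1OC`) gives 560 nM, the higher of the only two numbers so far. Compound 3 (`COc1cc(Sc2c[nH]c3ccc(N)cc23)cc(OC)c1OC`) keeps the shared core and differs from compound 2 by amino in place of nitro on an aromatic carbon. Going by the values given here, one measured step bears on this change, at the same aromatic carbon: a 7.3-fold higher number from compound 1 to compound 2 (0.86 log units; beyond the scatter). That step is modest but beyond the scatter, and it places the nitro compound on the weaker side. Among the compounds with values here, no measured compound carries amino, so the direction remains uncertain. Within the data shown here, removing nitro is nonetheless expected to give a modest step toward lower numbers, somewhat smaller than the one seen with compound 1. The expected change is a 3.1-fold lower number from compound 2 to compound 3 (0.49 log units; beyond the scatter). For compound 3 the estimated value is 180 nM, with an expected range of 50 nM to 650 nM.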

Compound 3, half-maximal inhibitory concentration: 260 nM
Compound 3: middle estimate off by 1.4-fold (0.16 log units), on the low side; the range from low to high includes it.
By their numbers in this assay, from the lowest: compound 1; then compound 3; then compound 2.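

In this assay, the place on the six-membered aromatic ring of carbon only now carries three read groups, and amino in place of nitro gives a 2.2-fold lower number from compound 2 to compound 3 (0.33 log units; beyond the scatter). Amino in place of chloro gives a 3.4-fold higher number from compound 1 to compound 3 (0.53 log units; beyond the scatter), so the amino compound falls between the other two, and chloro keeps the lowest number of the three, with both of its steps beyond the scatter. Nothing measured here accounts for this order of chloro, amino and nitro.

Open, from the compounds shown here alone, is how other groups at this place would fall in the order, such as fluoro, methoxy, a carboxylic acid or an acetamide. Also open, going by these compounds, is whether the same order would hold with a change elsewhere on the shared core.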